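Methyl in place of methoxy on the aromatic carbon

This account rests on a few compounds, and the source may have more. Where it says the series, first, only, none or still open, it means among the compounds named here.

Of the compounds shown here, three have been measured in a functional assay on SH-SY5Y cells (Homo sapiens) for cytotoxicity, read by MTT assay, with stated times of 8 h, 30 min and 12 h, tested at 0.5 uM; a higher number here means a stronger effect of the compound at the concentration tested, a lower number a weaker effect. Compound 1 `N=C(NCc1ccccc1)[C@@H]1CCC(=O)N1Cc1ccc([N+](=O)[O-])cc1` gives 24%, compound 2 `N=C(NCc1ccccc1)[C@@H]1CCC(=O)N1Cc1ccc(F)cc1` gives 23.3% and compound 3 `COc1ccc(CN2C(=O)CC[C@H]2C(=N)NCc2ccccc2)cc1` gives 21%. On the bare numbers compound 3 sits lowest of the three, but its steps to the other two are within the scatter: a number 3 percentage points lower from compound 1 to compound 3 (within the scatter) and a number 2.3 percentage points lower from compound 2 to compound 3 (within the scatter). The remaining measured step, a number 0.7 percentage points lower from compound 1 to compound 2 (within the scatter), is likewise within the scatter.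

Compound 4 `Cc1ccc(CN2C(=O)CC[C@H]2C(=N)NCc2ccccc2)cc1` differs from compound 3 as follows: methyl in place of methoxy on an aromatic carbon. Viewed one bond further out, 4-methoxyphenyl becomes 4-methylphenyl. For the measured compounds named here, no measured step involves methyl, so the only bearing comes from the three swaps at the same aromatic carbon, all of which stayed within the scatter in this assay. A further swap at that position is therefore expected to give no step beyond the scatter.

Compound 4 is estimated at 22% in this assay, with a range of 14% to 30%. This estimate corresponds to an expected a number 1 percentage points higher from compound 3 to compound 4 (within the scatter).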

Compound 4, a percentage reported as activity, at one concentration (the size of the read-out at that concentration, not a potency): 23.5%
Estimate against measurement, compound 4: 1.5 percentage points below; low and high end bracket the measured number.
By their numbers in this assay, from the lowest: compounds 3, 2, 4 and 1 (each within the scatter of the next).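

In this assay the step of a number 2.5 percentage points higher from compound 3 to compound 4 (within the scatter) stays within the scatter, as do a number 0.2 percentage points higher from compound 2 to compound 4 (within the scatter) and a number 0.5 percentage points lower from compound 1 to compound 4 (within the scatter), so methyl cannot be told apart from methoxy, fluoro or nitro on this aromatic carbon, para to a large group. The series now includes a swap that leaves a hydrogen-bond acceptor out of the group at this carbon, and that swap also stays within the scatter. No supporting data on hand account for this flat picture.

As far as these compounds go, whether an amine, a carboxylic acid or a longer chain on this aromatic carbon would give a step beyond the scatter stays open. Also open, from the compounds shown here alone, is whether the same flat picture would hold at other concentrations or for changes elsewhere on the shared core.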